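The compounds below may be only part of what the source reports. "The series", "measured", "known", "first", "only" and "open" are said of these compounds alone.

Compound 1 `O=Cc1cccc(OCc2cn(Cc3ccccc3)nn2)c1`
Compound 2 `O=C1Nc2cc(Cl)ccc2/C1=C\c1cccc(OCc2cn(Cc3ccccc3)nn2)c1`
Compound 3 `O=C1Nc2ccc(F)cc2/C1=C\c1cccc(OCc2cn(Cc3ccccc3)nn2)c1`

All three were tested in a functional assay on BT-549 cells (Homo sapiens) for inhibition, read by MTT assay, with a stated time of 48 h; on this read-out higher numbers stand for weaker inhibition and lower numbers for stronger inhibition. In this assay compound 1 gives > 50000 nM, which is a limit of the assay rather than a measured number. In this assay compound 2 gives > 50000 nM, again a limit. In this assay compound 3 gives > 50000 nM, also a limit. Among the compounds with values here, compound 3 therefore stands where every value shown stands, at the limit of > 50000 nM in this assay, at which 3 of the 3 values shown sit, and no step between measured compounds is available.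

The compound to be measured next is compound 4 `CC(=O)c1ccc2c(c1)/C(=C\c1cccc(OCc3cn(Cc4ccccc4)nn3)c1)C(=O)N2`. It differs from compound 3 in one place: acetyl in place of fluoro on an aromatic carbon, the carbon being part of a fused or bridged system of two rings, meta to a fused ring and para to a fused ring.

With no measured step to lean on and every value at the limit, the expectation for the step from compound 3 to compound 4 is none beyond the scatter, shown as a step that the limit leaves unreadable from compound 3 to compound 4. Compound 4 is expected to give about 60000 nM in this assay, within a range of 10000 nM to 200000 nM, most likely reported again as a limit.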

Compound 4, half-maximal inhibitory concentration: > 50000 nM
Compound 4 gave a limit, no number; the forecaster's own chance of this, stated with the estimate: 75%; the middle value does not contradict the limit.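

No step can be read from compound 3 to compound 4, since in this assay both compounds give only a limit and not a number: the limit of > 50000 nM in this assay, at which 4 of the 4 values shown sit.

How strong any of these compounds really is in this assay stays open, and so does whether acetyl in place of fluoro changes anything.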